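This account rests on a few compounds, and the source may have more. Where it says the series, first, only, none or still open, it means among the compounds named here.

Compound 1 `CCOc1c(-c2cc(OC)c(OC)c(OC)c2)oc2ccccc2c1=O`, compound 2 `CCC(C)Oc1c(-c2cc(OC)c(OC)c(OC)c2)oc2ccccc2c1=O` and compound 3 `CCCN(CCC)CCCOc1c(-c2cc(OC)c(OC)c(OC)c2)oc2ccccc2c1=O` share one core and differ only in the chain on its oxygen. In a functional assay on LNCaP cells (Homo sapiens) for antiproliferative activity, read by WST assay, with a stated time of 3 days (on this read-out lower numbers stand for stronger inhibition and higher numbers for weaker inhibition), compound 1 gives 5400 nM, compound 2 gives 9300 nM and compound 3 gives 17900 nM. Compound 3 lies at the upper end of this small set, but it stands clearly apart only from compound 1, with a 3.3-fold higher number from compound 1 to compound 3 (0.52 log units; beyond the scatter). Against compound 2 the data show a 1.9-fold higher number from compound 2 to compound 3 (0.28 log units; within the scatter), so those two cannot be told apart.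

Compound 4 `CCCCN(CCCC)CCCOc1c(-c2cc(OC)c(OC)c(OC)c2)oc2ccccc2c1=O` changes one thing: dibutylamino in place of dipropylamino on a saturated chain carbon, three bonds along the chain from an oxygen on an aromatic ring. Among the compounds with values here, no measured step swaps one such amino group for another, so the evidence is indirect. Even replacing sec-butyl with the whole 3-(dipropylamino)propyl group gave only a 1.9-fold higher number from compound 2 to compound 3 (0.28 log units; within the scatter), and the change from compound 1 to a branched chain gave a 1.7-fold higher number from compound 1 to compound 2 (0.24 log units; within the scatter). From the compounds shown here alone, a step beyond the scatter in this assay is therefore not expected, and the direction stays open, with only a slight lean towards a lower number. The estimated step is a 1.5-fold lower number from compound 3 to compound 4 (0.17 log units; within the scatter). For compound 4 the estimated value is 12000 nM, with an expected range from 4000 nM to 30000 nM.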

Compound 4, half-maximal inhibitory concentration: 9000 nM
The estimate for compound 4 lay 1.3-fold (0.12 log units) above the measured number; the range from low to high includes it.
By their numbers in this assay, from the lowest: compounds 1, 4, 2 and 3 (each within the scatter of the next, the first and the last beyond it).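

Within the data shown here, replacing dipropylamino with dibutylamino, on a saturated chain carbon, three bonds along the chain from an oxygen on an aromatic ring, gives the first direct comparison of two amino groups at this position: in this assay the result is a 2.0-fold lower number from compound 3 to compound 4 (0.30 log units; within the scatter), so the two amines cannot be told apart. Compound 4 also cannot be told apart from the compounds with simpler chains, with a 1.0-fold lower number from compound 2 to compound 4 (0.01 log units; within the scatter) and a 1.7-fold higher number from compound 1 to compound 4 (0.22 log units; within the scatter), whereas the dipropylamino chain had given a 3.3-fold higher number from compound 1 to compound 3 (0.52 log units; beyond the scatter), so a longer amine-bearing chain on this oxygen does not always stand clearly apart from the ethyl chain of compound 1. Nothing measured here explains these small differences.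

The compounds shown leave open whether a ring amine such as piperidine or morpholine, or a primary amine, in place of dibutylamino would produce a step beyond the scatter. They also leave open how a shorter 2-(dibutylamino)ethyl chain or a carboxylic acid at the chain end would read on this same oxygen.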